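Isobutyl for an alkene chain at the cytotoxicity limit

The source may hold more compounds than are shown below. What is called first, only, known or untested is meant among the compounds shown, and "the series" means these compounds.

Values in an ADME assay on Huh-7 cells (Homo sapiens) for cytotoxicity, with a stated time of 72 h (on this read-out higher numbers stand for lower toxicity in this test and lower numbers for higher toxicity in this test), each a limit and not a number:
- compound 1 `CC(C)CCn1nc(C2CCCC2)c(O)c(C2=NS(=O)(=O)c3cc(NS(C)(=O)=O)ccc3N2)c1=O` gives > 1000 nM
- compound 2 `CC(C)=Cc1nn(CCC(C)C)c(=O)c(C2=NS(=O)(=O)c3cc(NS(C)(=O)=O)ccc3N2)c1O` gives > 1000 nM

Compound 2 stands at > 1000 nM in this assay, which is a limit and not a number. Compound 3 `CC(C)CCn1nc(CC(C)C)c(O)c(C2=NS(=O)(=O)c3cc(NS(C)(=O)=O)ccc3N2)c1=O` has isobutyl in place of 2-methylprop-1-en-1-yl on an aromatic carbon. Among the measured compounds shown here, the one measured step that bears on this, a step that the two limits leave unreadable from compound 1 to compound 2, also swapped a group on an aromatic carbon, but it gives no usable size. The data show only (the limit of > 1000 nM in this assay, at which 2 of the 2 values shown sit). No clear direction is therefore expected, and the estimated step is a step that the limit leaves unreadable from compound 2 to compound 3. For compound 3 the estimate is 3000 nM, with an expected range from 1000 nM to 10000 nM.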

Compound 3, half-maximal cytotoxic concentration: > 1000 nM
Compound 3: no number, only a limit; the forecaster's own chance of this, stated with the estimate: 85%; the middle value lies beyond the limit too.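

No size can be read for any step among compound 1, compound 2 and compound 3, because all three stop at a limit and not a number: the limit of > 1000 nM in this assay, at which 3 of the 3 values shown sit. As far as these compounds go, whether cyclopentyl, 2-methylprop-1-en-1-yl and isobutyl differ at all in this assay stays open.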